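Urea substituent swap on the shared core

The source may hold more compounds than are shown below. What is called first, only, known or untested is meant among the compounds shown, and "the series" means these compounds.

Within the data shown here, the series shares one core, seen in compound 2 `O=C(NC1CCN(Cc2ccn(-c3ccc(C(F)(F)F)cc3)c2)CC1)N1CCCC(CO)C1`, which in an assay on HEK293 cells for displacement of a labelled ligand from melanin-concentrating hormone receptor 1 (Homo sapiens) (a higher number here means a weaker inhibitor, a lower number a stronger inhibitor), gives 23 nM, the lowest of the three numbers measured so far. Compound 1 `CN1CCN(C(=O)NC2CCN(Cc3ccn(-c4ccc(C(F)(F)F)cc4)c3)CC2)C(c2ccccc2)C1` gives 28 nM, within the scatter of compound 2. Compound 3 `O=C(NC1CCN(Cc2ccn(-c3ccc(C(F)(F)F)cc3)c2)CC1)N1CC[C@@H](O)C1` gives 138 nM; the step of a 6.0-fold higher number from compound 2 to compound 3 (0.78 log units; beyond the scatter) is the only measured one that alters the group on the carbonyl carbon.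

Compound 4 `O=C(NC[C@@H]1CCCC[C@H]1O)NC1CCN(Cc2ccn(-c3ccc(C(F)(F)F)cc3)c2)CC1` differs from compound 2 in this way: ((2-hydroxycyclohexyl)methyl)amino in place of 3-(hydroxymethyl)piperidin-1-yl on a carbonyl carbon. The nitrogen bonded to the carbonyl carbon is no longer part of a ring, and the hydroxyl now sits on the carbon ring. Among the measured compounds shown here, no measured step makes this exact change; the step from compound 2 to compound 3, also a change of the group on the carbonyl carbon, gave a modest weakening, and a step of similar kind is plausible here. A modest weakening, a 2.4-fold higher number from compound 2 to compound 4 (0.38 log units; beyond the scatter), is expected in this assay, with wide uncertainty. Compound 4 is estimated at 55 nM, ranging from 15 nM to 200 nM.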

Compound 4, half-maximal inhibitory concentration: 46 nM
Estimate against measurement, compound 4: 1.2-fold (0.08 log units) above; low and high end bracket the measured number.
By their numbers in this assay, from the lowest: compounds 2, 1 and 4 (each within the scatter of the next); then compound 3.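

In this assay, ((2-hydroxycyclohexyl)methyl)amino on the carbonyl carbon stands level with 3-(hydroxymethyl)piperidin-1-yl, a 2.0-fold higher number from compound 2 to compound 4 (0.30 log units; within the scatter), so for this pair a nitrogen held within a ring is not needed at this position. Among these compounds, the same group compares with 3-hydroxypyrrolidin-1-yl as a 3.0-fold lower number from compound 3 to compound 4 (0.48 log units; beyond the scatter), which leaves 3-hydroxypyrrolidin-1-yl as the one hydroxyl-bearing group set apart among compound 2, compound 3 and compound 4. No supporting data bear on why these numbers fall as they do.

On these data alone, whether the hydroxyl itself matters remains open, since all three of these groups carry one; a plain (cyclohexylmethyl)amino group, or an amine or carboxylic acid in its place, would address that. As far as these compounds go, how the two defined stereocentres of compound 4 bear on its number also remains open.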